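A few compounds are considered here, and "the series" means these few. Any claim that something is new, unique, unknown or untested is made for them only; others in the source may bear on it.

In a functional assay on MCF7 cells (Homo sapiens) for antiproliferative activity (a lower number here means a stronger inhibitor, a higher number a weaker inhibitor), compound 2 (`COc1ccc(-c2cn(C3Cc4ccc(O[C@@H]5OC(C)(C)[C@H](OC)[C@@H](O)[C@H]5O)c(C)c4OC3=O)nn2)cc1`) gives > 100000 nM, which is a limit of the assay and not a number. Compound 1 (`CO[C@@H]1[C@@H](O)[C@@H](O)[C@H](Oc2ccc3c(c2C)OC(=O)C(n2cc(-c4ccc(F)cc4F)nn2)C3)OC1(C)C`) gives > 100000 nM, also a limit. Compound 3 (`COc1cccc(-c2cc(-c3cn(C4Cc5ccc(O[C@@H]6OC(C)(C)[C@H](OC)[C@@H](O)[C@H]6O)c(C)c5OC4=O)nn3)ccc2OC)c1`) gives a true reading of 13200 nM.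

Compound 4 (`CO[C@@H]1[C@@H](O)[C@@H](O)[C@H](Oc2ccc3c(c2C)OC(=O)C(n2cc(-c4c[nH]c5ccccc45)nn2)C3)OC1(C)C`) now takes the series in a new direction, with 1H-indol-3-yl in place of 4-methoxyphenyl on an aromatic carbon of the five-membered aromatic ring with 3 nitrogen: 1H-indol-3-yl in place of 4-methoxyphenyl on an aromatic carbon.

Among the measured compounds shown here, two measured steps bear on this change. The exchange of 2,4-difluorophenyl for 4-methoxyphenyl at the same place is a step that the two limits leave unreadable from compound 1 to compound 2, so it gives no size to work from. For the measured compounds named here, the only readable step is an at least 7.5-fold lower number from compound 2 to compound 3 (0.87 log units; beyond the scatter), reached by putting 3-methoxyphenyl in place of hydrogen on an aromatic carbon. That step adds a whole further aromatic ring, whereas the present exchange adds far less, so only part of that gain is expected here, if any.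

The expected change is an at least 1.6-fold lower number from compound 2 to compound 4 (0.22 log units; that floor lies within the scatter), an estimated small move towards a lower number. A reading at the limit of the assay remains quite possible. Compound 4 is expected at about 60000 nM, with an estimated range of 15000 nM to 200000 nM.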

Compound 4, half-maximal inhibitory concentration: 18300 nM
Estimate against measurement, compound 4: 3.3-fold (0.52 log units) above; the range from low to high includes it.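

In this assay, the exchange for 1H-indol-3-yl gives an at least 5.4-fold lower number from compound 2 to compound 4 (0.73 log units; beyond the scatter), and it likewise gives an at least 5.4-fold lower number from compound 1 to compound 4 (0.73 log units; beyond the scatter). Among the compounds shown here, until this result, the only true reading belonged to compound 3, which carries a 3-methoxyphenyl group on top of its methoxy-substituted aromatic ring; compound 4 shows that a single exchange of the group on the five-membered aromatic ring with 3 nitrogen can also bring a reading within the range of the assay. Both steps give only a smallest size, not a full one, because compound 1 and compound 2 each stand at a limit of the assay: the limit of > 100000 nM in this assay, at which 2 of the 4 values shown sit.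

The compounds shown leave open whether the gain goes with the second aromatic ring of the 1H-indol-3-yl group or with the hydrogen-bond donor it brings, since the two enter together. On these data alone, a naphthyl group, which has two fused aromatic rings and no ring nitrogen, or a 1-methylindol-3-yl group at the same place would separate the two, and how far either would carry the series also remains open.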